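Aryl exchange on the five-membered ring: compound 3

The compounds below may be only part of what the source reports. "The series", "measured", "known", "first", "only" and "open" are said of these compounds alone.

Measured so far:
compound 1 `CS(=O)(=O)c1ccc(-c2cnc3[nH]cc(-c4nnc(-c5ccc(F)cc5)o4)c(=O)c3c2)cc1` — 8.47%
compound 2 `Cc1ccc(-c2nnc(-c3c[nH]c4ncc(-c5ccc(S(C)(=O)=O)cc5)cc4c3=O)o2)cc1` — 10.5%

In a functional assay on HeLa cells (Homo sapiens) for inhibition, read by MTT assay, with a stated time of 24 h, tested at 5 uM (on this read-out lower numbers stand for less inhibition of growth and higher numbers for more inhibition of growth at the one concentration tested), compound 1 gives 8.47%, the lowest of the two numbers available. Its nearest neighbour is compound 2, which gives 10.5%; the step of a number 2 percentage points higher from compound 1 to compound 2 (within the scatter) lies within the scatter, so the two values cannot be ordered.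

Compound 3 `Cc1cccc(-c2nnc(-c3c[nH]c4ncc(-c5ccc(S(C)(=O)=O)cc5)cc4c3=O)o2)c1` differs from compound 1 in one place: 3-methylphenyl in place of 4-fluorophenyl on an aromatic carbon. Among the compounds with values here, the only measured step that bears on this change is the one from compound 1 to compound 2, which also replaced fluoro with methyl on that aryl group and gave a number 2 percentage points higher from compound 1 to compound 2 (within the scatter), within the scatter. On that single precedent, and with no further data on this aryl group, no step beyond the scatter is expected for compound 3: a number 1.5 percentage points higher from compound 1 to compound 3 (within the scatter). The value expected for compound 3 is 10%, with a range from 2% to 20%.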

Compound 3, percent growth inhibition at one concentration: 1.49%
For compound 3 the middle estimate is 8.5 percentage points above the measured one, and the stated range ends above it.
By their numbers in this assay, from the lowest: compounds 3, 1 and 2 (each within the scatter of the next).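

Exchanging 4-fluorophenyl for 3-methylphenyl on the aromatic carbon of the five-membered ring gives no readable change in this assay: a number 7 percentage points lower from compound 1 to compound 3 (within the scatter). The exchange of 4-methylphenyl for 3-methylphenyl, which differs only in where the methyl stands on the phenyl ring, reads the same way: a number 9 percentage points lower from compound 2 to compound 3 (within the scatter). Across these three aryl groups, this position has therefore shown no step beyond the scatter, and no measurement at hand bears on the numbers.

Still open, going by these compounds, is whether this position responds to anything else, such as a phenyl ring carrying an amine or a carboxylic acid, or a longer chain in place of the aryl group. The three values also leave open how these compounds behave at any other concentration.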